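The source may report more compounds than this note shows. Statements on the series, on what has been measured and on what is new or still open speak of the compounds shown alone.

Three compounds share one core and differ only in the hydroxy-bearing chain on a five-membered aromatic ring with three nitrogens. In an assay on isolated protein for inhibition of Indoleamine 2,3-dioxygenase 1 (Homo sapiens) (on this read-out higher numbers stand for weaker inhibition and lower numbers for stronger inhibition), compound 1 `OCc1cn(CCNc2nonc2/C(=N/O)Nc2ccc(F)c(Br)c2)nn1` gives 77 nM; compound 2 `OCCCc1cn(CCNc2nonc2/C(=N/O)Nc2ccc(F)c(Br)c2)nn1` gives 98 nM; compound 3 `OCCCCc1cn(CCNc2nonc2/C(=N/O)Nc2ccc(F)c(Br)c2)nn1` gives 80 nM. Compound 1 holds the lowest of the three numbers, yet both others lie within the scatter of it: a 1.3-fold higher number from compound 1 to compound 2 (0.10 log units; within the scatter) and a 1.0-fold higher number from compound 1 to compound 3 (0.02 log units; within the scatter). Compound 4 `CC(OCCO)c1cn(CCNc2nonc2/C(=N/O)Nc2ccc(F)c(Br)c2)nn1` has not yet been measured. It differs from compound 1 by 1-(2-hydroxyethoxy)ethyl in place of hydroxymethyl on an aromatic carbon. The two measured steps from compound 1, which lengthen the chain that carries the hydroxy group, are the ones that bear on this change, and both stayed within the scatter. The entering group in compound 4 is larger than anything measured so far, but nothing in the measured steps points to a shift in either direction. A step of about a 1.2-fold higher number from compound 1 to compound 4 (0.07 log units; within the scatter) is therefore expected, that is, none beyond the scatter, and compound 4 is estimated at 90 nM, with a range from 40 nM to 220 nM.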

Compound 4, half-maximal inhibitory concentration: 134 nM
For compound 4 the middle estimate is 1.5-fold (0.17 log units) below the measured one; the range from low to high includes it.
By their numbers in this assay, from the lowest: compounds 1, 3, 2 and 4 (each within the scatter of the next).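

The measurements in this assay show that this aromatic carbon of the five-membered ring accepts more than a longer hydroxy-bearing chain. 1-(2-hydroxyethoxy)ethyl has 6 heavy atoms and 2 hydrogen-bond acceptors, against 2 heavy atoms and 1 acceptor in hydroxymethyl, yet every step to it stays within the scatter: (a 1.7-fold higher number from compound 1 to compound 4 (0.24 log units; within the scatter)), (a 1.7-fold higher number from compound 3 to compound 4 (0.22 log units; within the scatter)) and (a 1.4-fold higher number from compound 2 to compound 4 (0.14 log units; within the scatter)). No supporting measurement is available to explain these readings.

From the compounds shown here alone, all four compounds carry a hydroxy group at the end of an uncharged chain, so it remains open how an amine or a carboxylic acid at this position would read. Going by these compounds, it is also open whether a plain butyl chain, with no hydroxy group at all, would stay within the scatter.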